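Swapping chloro for methylpiperazinyl on a shared core

The source may report more compounds than this note shows. Statements on the series, on what has been measured and on what is new or still open speak of the compounds shown alone.

Measured compounds:
compound 1, `CC(=O)O[C@]1(C)/C=C/C(=O)/C(CO)=C\C[C@](C)(CCC=C(C)C)/C=C/[C@H]1OC(=O)C=C(C)C`, 3080 nM
compound 2, `CC(C)=CCC[C@]1(C)/C=C/[C@@H](OC(=O)C=C(C)C)[C@](C)(O)/C=C/C(=O)/C(CCl)=C\C1`, 840 nM

In a functional assay on SMMC-7721 cells (Homo sapiens) for antiproliferative activity, read by MTT assay, with a stated time of 48 h (on this read-out higher numbers stand for weaker inhibition and lower numbers for stronger inhibition), compound 1 gives 3080 nM while compound 2 gives 840 nM. Compound 2 holds the lower of the two numbers, and its gap to compound 1 lies beyond the usual scatter, so compound 2 is the stronger inhibitor of the pair. Compound 3, `CC(C)=CCC[C@]1(C)/C=C/[C@@H](OC(=O)C=C(C)C)[C@](C)(O)/C=C/C(=O)/C(CN2CCN(C)CC2)=C\C1`, is not yet measured. It differs from compound 2 in one place: 4-methylpiperazin-1-yl in place of chloro on a saturated chain carbon bound to a double-bonded ring carbon. For the measured compounds named here, no measured pair shows this change, so the expectation rests on compound 2 alone. In this assay the expected step is a 2.1-fold higher number from compound 2 to compound 3 (0.33 log units; beyond the scatter), a modest rise near the edge of the scatter. Compound 3 is estimated at 1800 nM, with a range from 450 nM to 7200 nM.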

Compound 3, half-maximal inhibitory concentration: 2940 nM
Beside the measured number, compound 3's estimate is 1.6-fold (0.21 log units) below it; the measured number falls inside the stated range.
By their numbers in this assay, from the lowest: compound 2; then compounds 3 and 1 (each within the scatter of the next).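

In this assay the place on a saturated chain carbon bound to a double-bonded ring carbon accepts a much larger group than chloro and still gives inhibition. Even so, 4-methylpiperazin-1-yl in place of chloro brings a 3.5-fold higher number from compound 2 to compound 3 (0.54 log units; beyond the scatter) as a modest weakening. Of these two groups, chloro gives the stronger inhibition at this place on the shared core.

Going by these compounds, whether a smaller amine such as dimethylamino or another ring such as morpholine would come closer to compound 2 remains open. No supporting measurement accounts for the size of this step.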